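Swapping Sulfamoyl for Methylsulfonyl on a Shared Core

The compounds below may be only part of what the source reports. "The series", "measured", "known", "first", "only" and "open" are said of these compounds alone.

The three measured compounds share one core and differ only at its edges. Compound 2 `Cc1ccc2nc(Nc3nc(Nc4ccc(S(N)(=O)=O)cc4)ncc3F)sc2c1` was tested in a functional assay on MCF7 cells (Homo sapiens) for antiproliferative activity, read by MTT assay, with a stated time of 48 h (a lower number here means a stronger inhibitor, a higher number a weaker inhibitor), and gave 24500 nM. Among the two plain numbers in this assay that is the higher one; compound 1 `CS(=O)(=O)c1ccc(Nc2ncc(F)c(Nc3nc4ccccc4s3)n2)cc1` gives 6880 nM, a gap that lies beyond the usual scatter. Compound 3 `Cc1ccc2nc(Nc3nc(Nc4ccc(S(N)(=O)=O)cc4)ncc3C)sc2c1` gives only a limit of the assay in this assay, > 50000 nM. The step of an at least 2.0-fold higher number from compound 2 to compound 3 (0.30 log units; that floor lies within the scatter) is therefore known only as a floor.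

Compound 4 `Cc1ccc2nc(Nc3nc(Nc4ccc(S(C)(=O)=O)cc4)ncc3F)sc2c1` has not yet been measured. Going by the values given here, it differs from compound 2 by methyl in place of amino on a sulfonyl sulfur, so that the same sulfamoyl-to-methylsulfonyl change that distinguishes compound 2 from compound 1 is applied here, although compound 1 and compound 2 also differ in a second place, so no single measured step covers the change. Among the compounds with values here, the only measured step, an at least 2.0-fold higher number from compound 2 to compound 3 (0.30 log units; that floor lies within the scatter), concerns a different position and a limit, and bears little on it. What the two values of compound 1 and compound 2 show is that the methylsulfonyl partner sits lower. Compound 4 is therefore expected to give a lower number than compound 2, by an estimated 2.2-fold lower number from compound 2 to compound 4 (0.35 log units; beyond the scatter), landing at about 11000 nM with a plausible range from 3500 nM to 40000 nM.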

Compound 4, half-maximal inhibitory concentration: > 50000 nM
Compound 4 ended at the assay's limit; the forecaster's own chance of this, stated with the estimate: 10%; middle value at least 4.5-fold (0.65 log units) from the limit.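

In this assay, as far as these compounds go, compound 4 gives only a limit of the assay, and the change of amino to methyl on the sulfonyl sulfur reads as an at least 2.0-fold higher number from compound 2 to compound 4 (0.30 log units; that floor lies within the scatter), so methylsulfonyl in place of sulfamoyl brings no lower number on this core, although the true size of the step stays unknown. The other single change, an added methyl on the shared core, reads as an at least 7.2-fold higher number from compound 1 to compound 4 (0.86 log units; beyond the scatter), and this shows that the lower number of compound 1 does not come with methylsulfonyl alone, since compound 4 carries that same group and differs from compound 1 only by this methyl. Compound 4 now stands at the same limit as compound 3, so no order between these two can be read: the limit of > 50000 nM in this assay, at which 2 of the 4 values shown sit.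

Still open is how far this methyl on the aromatic carbon moves the number when sulfamoyl stands on the other side of the molecule, since no pair shown tests that. Also open, from the compounds shown here alone, is how a larger or different group would read at either place, such as an ethyl chain or a dimethylamino group on the sulfonyl sulfur, or a chlorine or methoxy group on the aromatic carbon.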